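The compounds below may be only part of what the source reports. "The series", "measured", "known", "first", "only" and "open" are said of these compounds alone.

Measured compounds:
- compound 1 `O=c1cc(-c2ccccc2)oc2c(-c3cc(F)cc(F)c3)c(O)c(O)c(O)c12`: > 100000 nM
- compound 2 `O=c1cc(-c2ccc(Nc3ccc(F)cc3)cc2)oc2cc(O)c(O)c(O)c12`: > 100000 nM
- compound 3 `O=c1cc(-c2ccc(N3CCN(c4ccc(O)cc4)CC3)cc2)oc2cc(O)c(O)c(O)c12`: > 100000 nM

In a toxicity assay on Huh-7 cells (Homo sapiens) for cytotoxicity, read by CCK-8 assay, with a stated time of 24 h (on this read-out lower numbers stand for higher toxicity in this test and higher numbers for lower toxicity in this test), compound 1 gives > 100000 nM, and this is a limit of the assay rather than a measured number. Compound 2 gives > 100000 nM in this assay, again a limit. Compound 3 gives > 100000 nM, also a limit. Compound 1 therefore stands at the limit of > 100000 nM in this assay, at which 3 of the 3 values shown sit, so no toxicity has been seen for any of the three compounds within the tested range, and no ordering among them can be drawn.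

Compound 4 `Cc1cccc(-c2c(O)c(O)c(O)c3c(=O)cc(-c4ccccc4)oc23)c1` differs from compound 1 in one place: 3-methylphenyl in place of 3,5-difluorophenyl on an aromatic carbon. The two aryl groups are of similar size and neither carries donors or acceptors. Within the data shown here, no measured step between two compounds exists here to set the size of a change, and with all three values sitting at the limit, no step beyond the usual scatter is expected from compound 1 to compound 4.

Compound 4 is therefore expected to show a number no higher from compound 1 to compound 4 (the limit leaves the size open), giving an estimated value of 100000 nM, within a range of 40000 nM to 300000 nM, most likely reported again only as a limit.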

Compound 4, half-maximal cytotoxic concentration: > 100000 nM
Compound 4 gave a limit, no number; the forecaster's own chance of this, stated with the estimate: 85%; the middle value sits exactly at the limit.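

Compound 1 and compound 4 both sit at a limit of this assay, so putting 3-methylphenyl in place of 3,5-difluorophenyl gives no readable step between them. The compounds shown leave open at what concentration, if any, each becomes toxic to these cells, since all share one result: the limit of > 100000 nM in this assay, at which 4 of the 4 values shown sit.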